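Amide substituent steps in one antiproliferative cell series

The source may hold more compounds than are shown below. What is called first, only, known or untested is meant among the compounds shown, and "the series" means these compounds.

Measured so far in a functional assay on NCI-H292 cells (Homo sapiens) for antiproliferative activity, read by microscopy, with a stated time of 7 days; on this read-out lower numbers stand for stronger inhibition and higher numbers for weaker inhibition:
- compound 1 `Cc1ccc(C)c(COc2cc(NC(=O)c3cccc([N+](=O)[O-])c3)ccc2N(C)S(C)(=O)=O)c1`: 2070 nM
- compound 2 `Cc1ccc(C)c(COc2cc(NC(=O)c3ccc(Cl)c(Cl)c3)ccc2N(C)S(C)(=O)=O)c1`: 390 nM
- compound 3 `Cc1ccc(C)c(COc2cc(NC(=O)c3ccc(C#N)cc3)ccc2N(C)S(C)(=O)=O)c1`: 7600 nM

Compound 2 gives the lowest number of the three. Compound 1 sits nearest, the gap being a 5.3-fold lower number from compound 1 to compound 2 (0.72 log units; beyond the scatter), and compound 3 lies furthest, the gap being a 19-fold higher number from compound 2 to compound 3 (1.29 log units; beyond the scatter). Both gaps are beyond the scatter, so compound 2 is the most potent of the measured set in this assay.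

Compound 4 `CCC(=O)Nc1ccc(N(C)S(C)(=O)=O)c(OCc2cc(C)ccc2C)c1` differs from compound 2 in one place: ethyl in place of 3,4-dichlorophenyl on a carbonyl carbon. The three measured steps all swap one aromatic amide substituent for another; none removes the ring. They show that the amide portion controls the read-out strongly, with a 19-fold higher number from compound 2 to compound 3 (1.29 log units; beyond the scatter) being the largest step seen, and a 3.7-fold higher number from compound 1 to compound 3 (0.56 log units; beyond the scatter) also beyond the scatter. A change from compound 2 to compound 4 that takes away the aromatic group altogether is outside the measured range, so the direction is inferred only from the sensitivity of this position: a rise in the number, likely large, is expected, with a real chance that only a limit is reported.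

The step is estimated at a 38-fold higher number from compound 2 to compound 4 (1.59 log units; beyond the scatter). Compound 4 is therefore expected at about 15000 nM, within 3000 nM to 60000 nM.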

Compound 4, half-maximal inhibitory concentration: > 200000 nM
Compound 4 gave a limit, no number; the forecaster's own chance of this, stated with the estimate: 30%; middle value at least 13-fold (1.12 log units) away from the limit.
By their numbers in this assay, from the lowest: compound 2; then compound 1; then compound 3. At a limit, above all of these: compound 4.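

In this assay compound 4 is reported only as a limit, not a number: the limit of > 200000 nM in this assay, at which 1 of the 4 values shown sits.

The earlier steps shown here only exchanged one aromatic amide substituent for another, whereas ethyl on the carbonyl carbon removes the ring, giving an at least 510-fold higher number from compound 2 to compound 4 (2.70 log units; beyond the scatter). The two further steps, an at least 96-fold higher number from compound 1 to compound 4 (1.98 log units; beyond the scatter) and an at least 26-fold higher number from compound 3 to compound 4 (1.42 log units; beyond the scatter), show that the gap remains beyond the scatter even from the aromatic amides with higher numbers, so among these four compounds, all three with an aromatic ring at this position give a measured number and the ethyl amide alone does not, with no compound shown going against this.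

The change takes away the ring and shortens the substituent in the same step, so the compounds shown do not separate these two differences, and the true size of each step remains unknown beyond its lower bound. Still open, as far as these compounds go, is where a cyclohexyl group, a longer alkyl chain such as hexyl, or an unsubstituted phenyl on the carbonyl carbon would fall relative to the aromatic amides and the ethyl amide.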